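Swapping the Aryl Amine Group on a Shared Core

This account rests on a few compounds, and the source may have more. Where it says the series, first, only, none or still open, it means among the compounds named here.

Going by the values given here, compound 2 `FC(F)(F)c1ccc(CSc2nc(Nc3cccc(C(F)(F)F)c3)c3ccccc3n2)cc1` is one of two compounds tested so far in a functional assay on MDA-MB-231 cells (Homo sapiens) for cytotoxicity, read by MTT assay, with a stated time of 72 h; on this read-out higher numbers stand for weaker inhibition and lower numbers for stronger inhibition. In this assay, among the compounds with values here, compound 2 gives 11100 nM, which is the only actual number reported for this small set. Compound 1 `CCCCCCCCCCCCNc1nc(SCc2ccc(C(F)(F)F)cc2)nc2ccccc12`, which carries a long chain on the same nitrogen, reaches only a limit of the assay: in this assay compound 1 gives > 50000 nM. Within the data shown here, that is the limit at which one of the two values sits (the limit of > 50000 nM in this assay, at which 1 of the 2 values shown sits), so compound 2 stands as the single compound with a measured number.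

Compound 3 `CCOc1ccc(Nc2nc(SCc3ccc(C(F)(F)F)cc3)nc3ccccc23)cc1` has not yet been measured. It differs from compound 2 in one place: 4-ethoxyphenyl in place of 3-(trifluoromethyl)phenyl on a nitrogen on an aromatic ring. Among the measured compounds shown here, no measured pair of compounds shows a change of this kind, so there is no measured guide to its direction. For compound 3 the expected step is a 1.1-fold higher number from compound 2 to compound 3 (0.03 log units; within the scatter), that is, nothing beyond the usual scatter. Compound 3 is therefore expected to give about 12000 nM in this assay, within a range of 3500 nM to 40000 nM.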

Compound 3, half-maximal inhibitory concentration: 23000 nM
Estimate against measurement, compound 3: 1.9-fold (0.28 log units) below; the measured number falls inside the stated range.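

Going by these compounds alone, this pair gives the first readable step for a change of aryl group on the nitrogen on the aromatic ring: in this assay, 4-ethoxyphenyl in place of 3-(trifluoromethyl)phenyl gives a 2.1-fold higher number from compound 2 to compound 3 (0.32 log units; beyond the scatter). The step is modest, but it lies beyond the scatter, so this position does respond to the swap, and here the response is weaker inhibition. Compound 1 sits at a limit of the assay and not at a number, so no step involving it can be read: the limit of > 50000 nM in this assay, at which 1 of the 3 values shown sits.

Compound 2 and compound 3 differ in both the group on the aryl ring and the number that marks its place, so this one step cannot say whether the trifluoromethyl leaving, the ethoxy entering or the change of place matters most, and it gives no cause for the shift. Also open, as far as these compounds go, is how this assay would read for an unsubstituted phenyl on the same nitrogen, or for an aryl ring carrying an amine or a carboxylic acid.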